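The source may report more compounds than this note shows. Statements on the series, on what has been measured and on what is new or still open speak of the compounds shown alone.

Of the compounds shown here, three built on one shared core have been tested in a functional assay on M21 cells (Homo sapiens) for antiproliferative activity, read by sulforhodamine B assay, with a stated time of 48 h; on this read-out higher numbers stand for weaker inhibition and lower numbers for stronger inhibition. Compound 1 `CC(=O)Nc1ccc(S(=O)(=O)Oc2ccccc2I)cc1` gives 27000 nM. Compound 2 `CCCC(=O)Nc1ccc(S(=O)(=O)Oc2ccccc2I)cc1` gives 9000 nM. Compound 3 `CC(C)C(=O)Nc1ccc(S(=O)(=O)Oc2ccccc2I)cc1` gives 13000 nM, which places compound 3 second highest among the three numbers: the step of a 1.4-fold higher number from compound 2 to compound 3 (0.16 log units; within the scatter) lies within the scatter, while the step of a 2.1-fold lower number from compound 1 to compound 3 (0.32 log units; beyond the scatter) lies beyond it.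

Compound 4 `O=C(CCl)Nc1ccc(S(=O)(=O)Oc2ccccc2I)cc1` differs from compound 3 by one change: chloromethyl in place of isopropyl on a carbonyl carbon. Going by the values given here, no measured step involves a chlorine, so none bears on this change directly. What the measured steps do show is that enlarging the group on the carbonyl carbon lowered the number modestly, as in a 3.0-fold lower number from compound 1 to compound 2 (0.48 log units; beyond the scatter) and a 2.1-fold lower number from compound 1 to compound 3 (0.32 log units; beyond the scatter), whereas swapping one larger group for another, as in a 1.4-fold higher number from compound 2 to compound 3 (0.16 log units; within the scatter), made no difference beyond the scatter. Since the entering chloromethyl is nearer in size to the methyl of compound 1 than to the isopropyl of compound 3, the number for compound 4 is expected to drift back toward that of compound 1, a step of a 1.5-fold higher number from compound 3 to compound 4 (0.19 log units; within the scatter). The estimate for compound 4 in this assay is therefore 20000 nM, with a range from 7000 nM to 60000 nM.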

Compound 4, half-maximal inhibitory concentration: 3900 nM
The estimate for compound 4 lay 5.1-fold (0.71 log units) above the measured number; measured number outside the range, below it.
By their numbers in this assay, from the lowest: compound 4; then compounds 2 and 3 (each within the scatter of the next); then compound 1.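

In this assay chloromethyl on the carbonyl carbon gives the lowest number of the four compounds, with a 3.3-fold lower number from compound 3 to compound 4 (0.52 log units; beyond the scatter) and a 2.3-fold lower number from compound 2 to compound 4 (0.36 log units; beyond the scatter) and also a 6.9-fold lower number from compound 1 to compound 4 (0.84 log units; beyond the scatter). Among compounds 1, 2 and 3, only the larger carbon groups had lowered the number, but chloromethyl has fewer heavy atoms than isopropyl and still lowers it, so compound 4 goes against any reading of this position by group size alone. No measurement at hand explains what the chlorine contributes here.

The compounds shown leave open whether the lower number belongs to chlorine in particular, which fluoromethyl or bromomethyl on the same carbonyl carbon would test, and whether it persists when the chlorine sits at the end of a longer chain, as in 3-chloropropyl. They also leave open how the number would move with another atom on that chain carbon, as in methoxymethyl or aminomethyl.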